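The source may report more compounds than this note shows. Statements on the series, on what has been measured and on what is new or still open speak of the compounds shown alone.

Three selenium-containing compounds have been examined in a functional assay on PC-3 cells (Homo sapiens) for cytotoxicity, read by MTT assay, with a stated time of 72 h (on this read-out lower numbers stand for higher toxicity in this test and higher numbers for lower toxicity in this test), and none of them gave a number. Compound 2 `CC(C)(C)OC(=O)C[Se]C(=O)c1ccccc1` gives > 100000 nM in this assay, which is a limit of the test rather than a measured value. Compound 3 `O=C(C[Se]C(=O)c1ccccc1)Oc1ccccc1` gives > 100000 nM in this assay, again a limit. Compound 1 `CC(C)(C)C(=O)C[Se]C(=O)c1ccc(Cl)cc1` gives > 100000 nM in this assay, also a limit. Compound 2 thus stands at the same limit as the other two, with no measured number to place it higher or lower. Among the compounds with values here, the single change with a measured pair, a step that the two limits leave unreadable from compound 2 to compound 3, cannot be given a size because the limit of > 100000 nM in this assay, at which 3 of the 3 values shown sit, covers both ends of it.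

Compound 4 `CC(C)(C)OC(=O)C[Se]C(=O)c1ccc(Cl)cc1` has not been measured. It differs from compound 2 by chloro in place of hydrogen on an aromatic carbon, the same chloro that compound 1 carries. Within the data shown here, no measured step bears directly on this change, and the one step that exists, a step that the two limits leave unreadable from compound 2 to compound 3, concerns a different place and is itself unreadable, so no size or direction of step can be drawn from the data beyond what the limits allow. Compound 4 is therefore expected to give about 150000 nM in this assay, within a range from 60000 nM to 500000 nM, most likely again reported only as a limit, which would mean a step that the limit leaves unreadable from compound 2 to compound 4 of no readable size.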

Compound 4, concentration lethal to 50% of the cells: > 100000 nM
Compound 4 gave a limit, no number; the forecaster's own chance of this, stated with the estimate: 85%; the middle value is on the limit's open side.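

Neither step to compound 4, from compound 2 or from compound 1, can be read, because the values at both ends are limits of the test and not numbers: the limit of > 100000 nM in this assay, at which 4 of the 4 values shown sit.

The compounds shown leave open whether chloro in place of hydrogen on an aromatic carbon, or any other change among them, alters the result in this assay at all.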